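Swapping an amine substituent for a sulfonamide on the core

The source may hold more compounds than are shown below. What is called first, only, known or untested is meant among the compounds shown, and "the series" means these compounds.

Measured so far in an ADME assay on HepG2 2.2.15 cells (Homo sapiens) for cytotoxicity; on this read-out lower numbers stand for higher toxicity in this test and higher numbers for lower toxicity in this test:
- compound 1, `COCCc1ccc(OC(c2ccc(Cl)cc2)c2cnc(NC(=O)OC(C)(C)C)s2)cc1`: > 50000 nM
- compound 2, `Clc1ccc(C(Oc2ccc3cc(Br)ccc3c2)c2cnc(NCC3CCCCC3)s2)cc1`: "not toxic" (no number reported)
- compound 3, `COc1ccc(C(=O)Nc2ncc(C(Nc3cccc4ccccc34)c3ccc(Cl)cc3)s2)cc1`: > 50000 nM

Compound 1 reaches only a limit of this assay, > 50000 nM. Compound 3 likewise stops at a limit, > 50000 nM. Compound 2 carries no number at all, only the report "not toxic" (no number reported), so it stands on no scale of its own. The picture across all three is given by the limit of > 50000 nM in this assay, at which 2 of the 3 values shown sit.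

Compound 4, `O=S(=O)(Nc1ncc(C(Oc2ccc3cc(Br)ccc3c2)c2ccc(Cl)cc2)s1)c1cccs1`, has not yet been measured. It differs from compound 2 in one place: (thiophen-2-yl)sulfonyl in place of cyclohexylmethyl on a nitrogen on an aromatic ring. Among the compounds with values here, no pair of measured compounds shows what such a swap does in this assay, so the direction of any step is open. Since compound 2 shows no toxicity, and the other two compounds sit at the same limit, compound 4 is expected to sit near that limit as well, and a report of a limit rather than a number is more likely than not.

For compound 4 the estimate in this assay is 50000 nM, with a range from 15000 nM to 100000 nM.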

Compound 4, half-maximal cytotoxic concentration: "not toxic" (no number reported)
Nothing numeric was reported for compound 4; the estimate stays without a comparison.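

Compound 2 and compound 4 are both reported from this assay as "not toxic" without a number, so no step can be read between them. The compounds shown leave open whether replacing cyclohexylmethyl with (thiophen-2-yl)sulfonyl changes cytotoxicity at all. The only figures remain limits: the limit of > 50000 nM in this assay, at which 2 of the 4 values shown sit.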